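Swapping the order of ring atoms in a bicyclic ether group

The compounds below may be only part of what the source reports. "The series", "measured", "known", "first", "only" and "open" are said of these compounds alone.

Measured so far:
Compound 1 `C=C(F)C(=O)Nc1cc2c(Nc3ccc(Oc4cc5nncn5cn4)c(C)c3)ncnc2cc1OCC`: 3.88 nM
Compound 2 `Cc1cc(Nc2ncnc3cc(O)c(NC(=O)/C=C/[C@H]4CCCN4C)cc23)ccc1Oc1ccn2ncnc2c1`: 2.4 nM

Of the compounds shown here, two have been tested in a functional assay on BT-474 cells (Homo sapiens) for inhibition, read by CellTiter-Glo, with a stated time of 72 h; a lower number here means a stronger inhibitor, a higher number a weaker inhibitor. Compound 1 `C=C(F)C(=O)Nc1cc2c(Nc3ccc(Oc4cc5nncn5cn4)c(C)c3)ncnc2cc1OCC` gives 3.88 nM in this assay, and compound 2 `Cc1cc(Nc2ncnc3cc(O)c(NC(=O)/C=C/[C@H]4CCCN4C)cc23)ccc1Oc1ccn2ncnc2c1` gives 2.4 nM. Compound 2 has the lower of the two numbers, but the gap to compound 1 is within the scatter, so the two cannot be ranked against each other.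

Compound 3 `Cc1cc(Nc2ncnc3cc(O)c(NC(=O)/C=C/[C@H]4CCCN4C)cc23)ccc1Oc1ccn2cnnc2c1` has not yet been measured. It differs from compound 2 in one place, and the two contain the same atoms joined differently: a group of 9 heavy atoms (6 carbon, 3 nitrogen; one five-membered aromatic ring with 3 hetero atoms, one six-membered aromatic ring with 1 hetero atom) in place of a group of 9 heavy atoms (6 carbon, 3 nitrogen; one five-membered aromatic ring with 3 hetero atoms, one six-membered aromatic ring with 1 hetero atom), on an oxygen on an aromatic ring

Among the compounds with values here, no step between measured compounds is known, so there is no comparable change to lean on. The group that leaves and the group that enters match in every count given. The expectation is a step of no size beyond the scatter, in no particular direction. The estimated step is a 1.3-fold higher number from compound 2 to compound 3 (0.10 log units; within the scatter). Compound 3 is therefore expected to give about 3 nM in this assay, with a range from 1 nM to 10 nM.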

Compound 3, half-maximal inhibitory concentration: 26.8 nM
For compound 3 the middle estimate is 8.9-fold (0.95 log units) below the measured one; the measured number lies above the stated range.
By their numbers in this assay, from the lowest: compounds 2 and 1 (each within the scatter of the next); then compound 3.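

In this assay the group on an oxygen on an aromatic ring proves sensitive to how its ring atoms are joined, with a swap that gives an 11-fold higher number from compound 2 to compound 3 (1.05 log units; beyond the scatter) even though the group that leaves and the group that enters have the same atoms, the same ring sizes and the same counts of hydrogen-bond donors and acceptors. Counts of this kind therefore do not settle the outcome at this position, since two groups that match in all of them still differ by a large step here. No measurement shown here accounts for the step, and what lies behind it remains unknown.

Within the data shown here, this is a single pair, so it remains open whether a step of this size would also appear if the same swap were made on a compound with a different amide side chain, such as the one in compound 1. From the compounds shown here alone, it is also open how a simpler group on that oxygen, such as a phenyl or pyridine ring, would compare with the two groups seen so far.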